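A few compounds are considered here, and "the series" means these few. Any claim that something is new, unique, unknown or untested is made for them only; others in the source may bear on it.

Within the data shown here, compound 3, `N=C(NCCCc1c[nH]cn1)NCCC(c1cccc(C(F)(F)F)c1)c1ccccn1`, sits second highest of the three values so far in a functional assay on muscle tissue for agonist activity at histamine H2 receptor (Cavia porcellus) (a lower number here means a less potent compound, a higher number a more potent compound, by a factor of ten per unit of this negative logarithm), giving 7.44. Its nearest neighbour is compound 2, `N=C(NCCCc1c[nH]cn1)NCCC(c1cccc(F)c1)c1ccccn1`, at 7.79, reached through the step of a number 0.35 log units lower from compound 2 to compound 3 (beyond the scatter). Furthest is compound 1, `N=C(NCCCc1c[nH]cn1)NCCC(c1ccc(Br)cc1)c1ccccn1`, at 6.97; the step of a number 0.47 log units higher from compound 1 to compound 3 (beyond the scatter), and a number 0.82 log units higher from compound 1 to compound 2 (beyond the scatter), place both fluorinated rings above the bromophenyl.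

Compound 4, `N=C(NCCCc1c[nH]cn1)NCCC(c1cc(F)cc(F)c1)c1ccccn1`, differs from compound 3 as follows: 3,5-difluorophenyl in place of 3-(trifluoromethyl)phenyl on a saturated chain carbon bound to an aromatic carbon and a saturated chain carbon. The step that bears most directly is a number 0.35 log units lower from compound 2 to compound 3 (beyond the scatter), since compound 4 returns to a fluoro on the ring and adds a second; the two rising steps from compound 1 set the general direction. A modest gain is therefore expected, a number 0.16 log units higher from compound 3 to compound 4 (within the scatter), landing between compound 3 and compound 2. Compound 4 is estimated at 7.6, within 7.1 to 8.1.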

Compound 4, negative logarithm of the half-maximal effective concentration: 7.91
Estimate against measurement, compound 4: 0.31 log units below, and the stated range covers the measured number.
By their numbers in this assay, from the lowest: compound 1; then compound 3; then compounds 2 and 4 (each within the scatter of the next).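

In this assay, the 3,5-difluorophenyl ring on the saturated chain carbon restores what the 3-(trifluoromethyl)phenyl ring gave up (a number 0.47 log units higher from compound 3 to compound 4 (beyond the scatter)). Adding a second fluoro to the ring gives no difference that can be told apart from the single fluoro (a number 0.12 log units higher from compound 2 to compound 4 (within the scatter)), so compound 2 and compound 4 stand level. The 3,5-difluorophenyl ring also gives the largest step from the 4-bromophenyl ring so far (a number 0.94 log units higher from compound 1 to compound 4 (beyond the scatter)). Nothing measured here accounts for these differences. Open, on these data alone, is how a chloro or methoxy on this ring would compare with the two fluoro compounds.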